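From a Six-Membered to a Five-Membered Ring

This account rests on a few compounds, and the source may have more. Where it says the series, first, only, none or still open, it means among the compounds named here.

Compound 1 `Cc1c(C)c2c(c(C)c1OC(=O)CCC(=O)NC1CC(C)(C)N([O])C(C)(C)C1)CC[C@@](C)(CCC[C@H](C)CCC[C@H](C)CCCC(C)C)O2` was tested in a functional assay on RPMI-8226 cells (Homo sapiens) for cytotoxicity, read by MTT assay, with a stated time of 72 h; a lower number here means a stronger inhibitor, a higher number a weaker inhibitor. There, compound 1 gives > 300000 nM, which is a limit and not a number. Compound 2 `CC1(C)CC(NC(=O)CCC(=O)O)CC(C)(C)N1[O]` gives > 300000 nM, which is also a limit. Compound 3 `Cc1c(C)c2c(c(C)c1OC(=O)CCC(=O)NCC1CC(C)(C)N([O])C1(C)C)CC[C@@](C)(CCC[C@H](C)CCC[C@H](C)CCCC(C)C)O2` has the same atoms as compound 1, joined differently: a group of 11 heavy atoms (9 carbon, 1 nitrogen, 1 oxygen; one five-membered non-aromatic ring with 1 hetero atom) in place of a group of 11 heavy atoms (9 carbon, 1 nitrogen, 1 oxygen; one six-membered non-aromatic ring with 1 hetero atom), on an amide-type nitrogen. Going by the values given here, no measured step shows what this change does. The expectation therefore rests on the limit of compound 1, > 300000 nM, and is for no step beyond the scatter in this assay. The expected step is a number no higher from compound 1 to compound 3 (the limit leaves the size open). For compound 3, the estimated value is 300000 nM, with an expected range from 100000 nM to 600000 nM.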

Compound 3, half-maximal inhibitory concentration: 217000 nM
Estimate against measurement, compound 3: 1.4-fold (0.14 log units) above; low and high end bracket the measured number.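

Going by these compounds alone, with the five-membered ring in place of the six-membered ring on the amide-type nitrogen, this assay shows an at least 1.3-fold lower number from compound 1 to compound 3 (0.14 log units; that floor lies within the scatter) and so gives compound 3 a number where the earlier compounds gave only limits. On these data alone, the real size of this step stays unknown because compound 1 has only a limit and no number of its own: the limit of > 300000 nM in this assay, at which 2 of the 3 values shown sit. As far as these compounds go, whether a simple amine or a longer chain in place of either ring on the amide-type nitrogen would give a clearly lower number remains open.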